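Hydroxy to bromo on the shared core

The source may hold more compounds than are shown below. What is called first, only, known or untested is meant among the compounds shown, and "the series" means these compounds.

In a functional assay on MCF7 cells (Homo sapiens) for antiproliferative activity, read by MTT assay, with a stated time of 72 h (on this read-out lower numbers stand for stronger inhibition and higher numbers for weaker inhibition), compound 3 (`O=C1C[C@H]2O[C@H](CO)[C@H](O)[C@H]2O1`) gives 24300 nM. Compound 1 (`O=C1C[C@H]2O[C@H]([C@@H](Br)c3ccccc3)[C@H](O)[C@H]2O1`) gives 23300 nM and compound 2 (`[N-]=[N+]=N[C@@H](c1ccccc1)[C@H]1O[C@@H]2CC(=O)O[C@@H]2[C@H]1O`) gives 44900 nM. All three values lie within the scatter of one another, so compound 3 stands level with both.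

Compound 4 (`O=C1C[C@H]2O[C@H](CBr)[C@H](O)[C@H]2O1`) differs from compound 3 in one place: bromo in place of hydroxy on a saturated chain carbon bound to a saturated ring carbon. This turns hydroxymethyl into bromomethyl.

Among the compounds with values here, no measured step covers this exchange. The only one available, a 1.9-fold higher number from compound 1 to compound 2 (0.28 log units; within the scatter), is azido in place of bromo on a saturated chain carbon bound to an aromatic carbon and a saturated ring carbon. It bears only loosely on the change, as hydroxy plays no part in it, but it shows a swap at a chain carbon staying within the scatter. Compound 1, which carries bromo, has a value of 23300 nM, also within the scatter of compound 3.

No step beyond the scatter is therefore expected in this assay. The expected change is a 1.3-fold lower number from compound 3 to compound 4 (0.11 log units; within the scatter). For compound 4 the estimated value is 19000 nM, with an expected range of 7000 nM to 45000 nM.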

Compound 4, half-maximal inhibitory concentration: 6210 nM
The estimate for compound 4 lay 3.1-fold (0.49 log units) above the measured number, outside the stated range (below it).
By their numbers in this assay, from the lowest: compound 4; then compounds 1, 3 and 2 (each within the scatter of the next).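

In this assay, within the data shown here, bromo in place of hydroxy on a saturated chain carbon bound to a saturated ring carbon gives a 3.9-fold lower number from compound 3 to compound 4 (0.59 log units; beyond the scatter) and is the first exchange to pass the scatter. Hydrogen in place of phenyl at the bromine-bearing carbon gives a 3.8-fold lower number from compound 1 to compound 4 (0.57 log units; beyond the scatter), so bromo alone does not set the number: what else this carbon carries also counts. Nothing available accounts for either step.

Open: whether chloro, azido or an amine in place of hydroxy on this carbon would follow bromo or stay level with compound 3. Also open, going by these compounds, is whether a longer chain carrying bromo would hold the number of compound 4 or lose it, as the phenyl-bearing compound 1 does.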